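The compounds below may be only part of what the source reports. "The series", "measured", "known", "first", "only" and "open" are said of these compounds alone.

Measured so far in a functional assay for antagonist activity at Neuropeptide Y receptor type 2 (Homo sapiens); on this read-out lower numbers stand for stronger inhibition and higher numbers for weaker inhibition:
- compound 1, `COc1ccc(OC(=O)N2CCC(C(O)(c3ccccc3)c3ccccc3)CC2)cc1`, giving 2680 nM
- compound 2, `CCOc1ccc(OC(=O)N2CCC(C(O)(c3ccccc3)c3ccccc3)CC2)cc1`, giving 1580 nM
- compound 3, `CS(=O)(=O)c1ccc(OC(=O)N2CCC(C(O)(c3ccccc3)c3ccccc3)CC2)cc1`, giving 141 nM

The three compounds share the core of compound 1, and the substituent on the aromatic ring is the only variable. Compound 3 stands lowest of the three in this assay: a 19-fold lower number from compound 1 to compound 3 (1.28 log units; beyond the scatter), and an 11-fold lower number from compound 2 to compound 3 (1.05 log units; beyond the scatter). The difference between the core of compound 1 and the core of compound 3 is methylsulfonyl in place of methoxy on an aromatic carbon.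

The step from compound 1 to compound 2 is methyl in place of hydrogen on a saturated chain carbon bound to an oxygen on an aromatic ring; it gave a 1.7-fold lower number from compound 1 to compound 2 (0.23 log units; within the scatter).

Compound 4, `CCS(=O)(=O)c1ccc(OC(=O)N2CCC(C(O)(c3ccccc3)c3ccccc3)CC2)cc1`, is not yet measured. It differs from compound 3 by methyl in place of hydrogen on a saturated chain carbon bound to a sulfonyl sulfur. This is the same kind of change as that from compound 1 to compound 2, not the same change: there the carbon is bound to an oxygen on an aromatic ring, here it is bound to a sulfonyl sulfur. Among the measured compounds shown here, no other pair carries this change, so the single earlier step is the only guide.

For compound 4 in this assay the expected step is a 1.4-fold lower number from compound 3 to compound 4 (0.15 log units; within the scatter), set beside a 1.7-fold lower number from compound 1 to compound 2 (0.23 log units; within the scatter), and rests on that earlier step lying within the scatter. Compound 4 is therefore estimated at 100 nM, with a range from 40 nM to 300 nM expected.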

Compound 4, half-maximal inhibitory concentration: 59 nM
Beside the measured number, compound 4's estimate is 1.7-fold (0.23 log units) above it; measured number inside the range.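

In this assay, methyl in place of hydrogen on a saturated chain carbon bound to a sulfonyl sulfur gives a 2.4-fold lower number from compound 3 to compound 4 (0.38 log units; beyond the scatter), while ethylsulfonyl in place of ethoxy gives a 27-fold lower number from compound 2 to compound 4 (1.43 log units; beyond the scatter) and ethylsulfonyl in place of methoxy gives a 45-fold lower number from compound 1 to compound 4 (1.66 log units; beyond the scatter). The methyl change therefore carries from the ethoxy and methoxy pair to the sulfonyl pair with no difference in step size that can be told apart, although the carbon it sits on is bound to a different atom in each case: the same change on two cores in this assay, a 1.7-fold lower number (0.23 log units; within the scatter) from compound 1 to compound 2 and a 2.4-fold lower number (0.38 log units; beyond the scatter) from compound 3 to compound 4, 1.4-fold (0.15 log units) apart, within the scatter of two such steps. Among the compounds shown here, this rests on only two steps, one within the scatter and one beyond it, so it shows agreement on these two cores but gives no rule for any other core and no reason for the size of either step.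

The compounds shown leave open whether a longer chain on the sulfonyl sulfur, such as propyl or isopropyl, would extend the step from methylsulfonyl to ethylsulfonyl or reverse it. Also open, on these data alone, is how a sulfonamide or a carboxylic acid would compare with ethylsulfonyl on the shared core.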